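The compounds below may be only part of what the source reports. "The series", "measured", "known", "first", "only" and "open" are said of these compounds alone.

In a functional assay on FM3A cells (Mus musculus) for antiproliferative activity (on this read-out higher numbers stand for weaker inhibition and lower numbers for stronger inhibition), compound 1 `COc1cccc(-c2cc(N)c(C(=O)c3cc(OC)c(OC)c(OC)c3)s2)c1` gives 36 nM while compound 2 `CCOc1ccc(-c2cc(N)c(C(=O)c3cc(OC)c(OC)c(OC)c3)s2)cc1` gives 510 nM and so holds the higher of the two numbers. Compound 3 `COc1cc(C(=O)c2sc(-c3ccc(C(F)(F)F)cc3)cc2N)cc(OC)c1OC` has trifluoromethyl in place of ethoxy on an aromatic carbon and otherwise matches compound 2. Going by the values given here, the one measured step, a 14-fold higher number from compound 1 to compound 2 (1.15 log units; beyond the scatter) is large, but it swapped 3-methoxyphenyl for 4-ethoxyphenyl and does not test this exchange directly. No clear move in this assay is therefore expected in either direction. The expected change is a 1.0-fold lower number from compound 2 to compound 3 (0.01 log units; within the scatter) and stays within the scatter. For compound 3 the estimate is 500 nM with an expected range from 120 nM to 2000 nM in this test.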

Compound 3, half-maximal inhibitory concentration: 540 nM
The estimate for compound 3 lay 1.1-fold (0.03 log units) below the measured number, within the range that was stated.
By their numbers in this assay, from the lowest: compound 1; then compounds 2 and 3 (each within the scatter of the next).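

Swapping ethoxy for trifluoromethyl on the phenyl ring gives a 1.1-fold higher number from compound 2 to compound 3 (0.02 log units; within the scatter), so in this assay these two groups cannot be told apart at this place, although they differ in their atoms and in hydrogen-bond acceptor count. The other new step, a 15-fold higher number from compound 1 to compound 3 (1.18 log units; beyond the scatter), is large, so compound 3, like compound 2, stands well above compound 1. No supporting evidence bears on this result.

Going by these compounds, whether the gap to compound 1 depends on where the group sits or on which group it is stays open. A 4-aminophenyl or 4-carboxyphenyl group could also read differently here.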